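A few compounds are considered here, and "the series" means these few. Any claim that something is new, unique, unknown or untested is made for them only; others in the source may bear on it.

Measured so far in a functional assay on NCI-H460 cells (Homo sapiens); a lower number here means that less compound is needed, a higher number that more compound is needed for the effect:
- compound 1 `COC(=O)N1N=C(c2ccc(N(C)C)cc2)OC1c1cc(OC)c(OC)c(OC)c1`: 106 uM
- compound 2 `COc1cc(C2OC(c3ccc(N(C)C)cc3)=NN2C(=O)CN=[N+]=[N-])cc(OC)c1OC`: 0.53 uM

Compound 2 holds the lower of the two numbers, at 0.53 uM. The next compound to test is compound 3 `COc1cc(C2OC(c3ccc(N(C)C)cc3)=NN2C(=O)CNC=O)cc(OC)c1OC`, with formylamino in place of azido on a saturated chain carbon bound to a carbonyl carbon.

Among the measured compounds shown here, only one measured step bears on this change, a 200-fold lower number from compound 1 to compound 2 (2.30 log units; beyond the scatter), which is large. It shows that the number in this assay can move far when the group on that carbonyl carbon changes, but it does not compare azido with formylamino. A moderate step to a higher number is expected, smaller than that measured step, though the data leave this uncertain. The expected change is a 5.7-fold higher number from compound 2 to compound 3 (0.75 log units; beyond the scatter). For compound 3 the estimate is 3 uM, with an expected range of 0.4 uM to 25 uM.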

Compound 3, concentration for half-maximal effect: 0.04 uM
Compound 3: middle estimate off by 75-fold (1.88 log units), on the high side; the whole stated range lies above it.
By their numbers in this assay, from the lowest: compound 3; then compound 2; then compound 1.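

In this assay, azido is not needed on the saturated chain carbon bound to a carbonyl carbon: formylamino in its place gives a 13-fold lower number from compound 2 to compound 3 (1.12 log units; beyond the scatter) and sets the lowest number of the three compounds. Against the methoxy on the carbonyl carbon of compound 1, (formylamino)methyl gives a 2700-fold lower number from compound 1 to compound 3 (3.42 log units; beyond the scatter), which extends the range of this position well beyond that seen with azidomethyl. No measured data here account for either step.

The azido to formylamino change also adds one hydrogen-bond donor, and this single pair cannot show whether the amide hydrogen matters. Also open, as far as these compounds go, is how a free amine, an acetylamino group or a longer chain would compare with formylamino on the same carbon.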